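Permeability of a urea series: removing a hydroxyl

A few compounds are considered here, and "the series" means these few. Any claim that something is new, unique, unknown or untested is made for them only; others in the source may bear on it.

Compounds measured so far:
Compound 1, `Cc1cc(NC(=O)Nc2ccc(Cl)c(Cl)c2)c2ccccc2n1`, gives 197 10^-6 cm/s.
Compound 2, `Cc1cc(NC(=O)Nc2ccc(O)cc2)c2ccccc2n1`, gives 3 10^-6 cm/s.

Both numbers come from an ADME assay for permeability, using PAMPA, at pH 7.4; on this read-out higher numbers stand for higher permeability and lower numbers for lower permeability. Compound 2 stands at the lower of the two values, and its gap to compound 1 lies well beyond the usual scatter of this assay.

Compound 3, `Cc1cc(NC(=O)Nc2cccc(Cl)c2)c2ccccc2n1`, has not yet been measured. It differs from compound 2 in one place: 3-chlorophenyl in place of 4-hydroxyphenyl on an amide-type nitrogen. The group that leaves carries a hydrogen-bond donor and acceptor; the group that enters carries none, like the group found in compound 1.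

Among the measured compounds shown here, with no step between measured compounds to lean on, the expectation rests on compound 1, whose 197 10^-6 cm/s was obtained with a chlorine-bearing ring and no donor or acceptor in this place. A large upward step, a 40-fold higher number from compound 2 to compound 3 (1.60 log units; beyond the scatter), is therefore expected. Compound 3 is estimated at 120 10^-6 cm/s, within 40 10^-6 cm/s to 250 10^-6 cm/s.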

Compound 3, apparent permeability: 566 10^-6 cm/s
Compound 3: the middle estimate sits 4.7-fold (0.67 log units) below what was measured; measured number above the stated range.
By their numbers in this assay, from the lowest: compound 2; then compound 1; then compound 3.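

In this assay, 3-chlorophenyl in place of 4-hydroxyphenyl on an amide-type nitrogen gives a 190-fold higher number from compound 2 to compound 3 (2.28 log units; beyond the scatter) and so supplies the first direct one-place reading: exchanging this ring alone can move the number enormously. A further chloro is not needed for a high number here, since hydrogen in place of chloro on an aromatic carbon gives a 2.9-fold higher number from compound 1 to compound 3 (0.46 log units; beyond the scatter) as a modest step that still lies beyond the scatter. Nothing shown gives a measured reason for the size of either step.

From the compounds shown here alone, the large step changes both the group on the ring and its numbered place, so it remains open how much each contributes, and 3-hydroxyphenyl or 4-chlorophenyl would separate the two. Going by these compounds, how a ring carrying an amine or a carboxylic acid would read also remains open.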